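The source may report more compounds than this note shows. Statements on the series, on what has been measured and on what is new or still open speak of the compounds shown alone.

Compound 1 `COc1ccc(-c2cc3c(OC)cc(OC)cc3n(C)c2=O)cc1` and compound 2 `CCN(CC)C(=O)Cn1c(=O)c(-c2ccc(OC)cc2)cc2c(OC)cc(OC)cc21` share one core and differ only at a saturated chain carbon bound to an aromatic nitrogen. In a functional assay on PC-3 cells (Homo sapiens) for cytotoxicity, read by colorimetric assay and MTT assay (on this read-out lower numbers stand for stronger inhibition and higher numbers for weaker inhibition), compound 1 gives 10000 nM, and in this assay compound 2 gives 10000 nM. The step of no change at the digits printed from compound 1 to compound 2 (within the scatter) shows that placing a diethylcarbamoyl group there changed nothing beyond the scatter, so compound 2 stands level with compound 1 on these numbers. Compound 3 `COc1ccc(-c2cc3c(OC)cc(OC)cc3n(CC#N)c2=O)cc1` carries cyano in place of diethylcarbamoyl on a saturated chain carbon bound to an aromatic nitrogen. Within the data shown here, the only measured step that bears on this place, no change at the digits printed from compound 1 to compound 2 (within the scatter), was flat, so a second exchange at the same place is expected to leave this assay unchanged as well, and the expected step is no change at the digits printed from compound 2 to compound 3 (within the scatter). Compound 3 is therefore estimated at 10000 nM in this assay, with an expected range from 5000 nM to 20000 nM.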

Compound 3, half-maximal inhibitory concentration: 10000 nM
Compound 3: the middle estimate sits on the measured number at the digits printed, and the stated range covers the measured number.
By their numbers in this assay, from the lowest: compounds 1, 2 and 3 (each within the scatter of the next).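

Replacing diethylcarbamoyl with cyano on a saturated chain carbon bound to an aromatic nitrogen gives no change at the digits printed from compound 2 to compound 3 (within the scatter) in this assay, so this much smaller group with a triple bond does no differently here from the larger amide-bearing group. Cyano in place of hydrogen at the same carbon gives no change at the digits printed from compound 1 to compound 3 (within the scatter), which means that two quite different groups now sit level with the hydrogen of compound 1, and this position has stayed flat through both exchanges. Nothing available explains why the numbers stay level.

As far as these compounds go, whether an amine, a carboxylic acid or a longer chain at this place would move the number in this assay remains open. So does whether replacing the methoxy groups on the shared core would move it.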